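This account rests on a few compounds, and the source may have more. Where it says the series, first, only, none or still open, it means among the compounds named here.

Measured in a functional assay on MCF7 cells (Homo sapiens) for inhibition, read by WST assay, with a stated time of 72 h; on this read-out higher numbers stand for weaker inhibition and lower numbers for stronger inhibition:
- Compound 1 `N#C/N=C(\NCCCCCCC(=O)NOC1CCCCC1)Nc1ccncc1`: 940 nM
- Compound 2 `N#C/N=C(\NCCCCCCC(=O)N(Cc1ccccc1)OC1CCCCC1)Nc1ccncc1`: 1 nM

Of these two, compound 1 has the higher number and is therefore the weaker inhibitor. Compound 3 `N#C/N=C(\NCCCCC[C@@H](Cc1ccccc1)C(=O)NOC1CCCCC1)Nc1ccncc1` keeps the core of compound 1 and differs from it by benzyl in place of hydrogen on a saturated chain carbon bound to a carbonyl carbon and a saturated chain carbon. Within the data shown here, one measured step bears on this change: a 940-fold lower number from compound 1 to compound 2 (2.97 log units; beyond the scatter). That large step also brings in a benzyl, but on an amide-type nitrogen rather than on a saturated chain carbon, so it is only a loose guide. Among the measured compounds shown here, no measured compound carries a group at the new place. A drop in this assay is therefore expected, in the same direction but much smaller. The expected change is a 12-fold lower number from compound 1 to compound 3 (1.07 log units; beyond the scatter). For compound 3 the estimated value is 80 nM, with an expected range from 4 nM to 1500 nM.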

Compound 3, half-maximal inhibitory concentration: 5.3 nM
Beside the measured number, compound 3's estimate is 15-fold (1.18 log units) above it, and the stated range covers the measured number.
By their numbers in this assay, from the lowest: compound 2; then compound 3; then compound 1.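

In this assay, the saturated chain carbon bound to a carbonyl carbon and a saturated chain carbon proves to be a place where the change matters greatly: benzyl in place of hydrogen there gives a 180-fold lower number from compound 1 to compound 3 (2.25 log units; beyond the scatter). A large drop on adding a benzyl is therefore not confined to the amide-type nitrogen, where the change gives a 940-fold lower number from compound 1 to compound 2 (2.97 log units; beyond the scatter). Nothing available explains why benzyl lowers the number at either place.

The compounds shown leave open whether the six-membered aromatic ring of the benzyl is needed at the chain carbon, which a methyl or a cyclohexylmethyl there would test. They also leave open how the opposite configuration at that carbon, or a benzyl at both places together, would read in this assay.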